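A few compounds are considered here, and "the series" means these few. Any claim that something is new, unique, unknown or untested is made for them only; others in the source may bear on it.

In an in vitro ADME assay on microsomes (Homo sapiens) for metabolic stability, read by LC-MS, with a stated time of 15 min (a higher number here means that the compound lasts longer, a lower number that the compound disappears faster), compound 1 `CN1CCN(c2ccc(NC(=O)Nc3ccc(-c4nc(N5C6CCC5COC6)nc(N5[C@H](CO)CC[C@@H]5CO)n4)cc3)cc2)CC1` gives 0.0917 h. Compound 2 `CCN1CCN(c2ccc(NC(=O)Nc3ccc(-c4nc(C5CCOCC5)nc(N5C6CCC5COC6)n4)cc3)cc2)CC1` gives > 0.5 h, which is a limit of the assay and not a number. Compound 2 therefore has no exact reading, and its place on the numbers is this: the limit of > 0.5 h in this assay, at which 1 of the 2 values shown sits. Compound 3 `CC(C)N1CCN(c2ccc(NC(=O)Nc3ccc(-c4nc(C5CCOCC5)nc(N5C6CCC5COC6)n4)cc3)cc2)CC1` departs from compound 2 in a single place, where ethyl becomes isopropyl, turning the 4-ethylpiperazin-1-yl into a 4-isopropylpiperazin-1-yl: methyl in place of hydrogen on a saturated chain carbon bound to an amine nitrogen in a ring and a saturated chain carbon. For the measured compounds named here, no measured pair in this small set differs in one place only, so the expectation rests on the size of that change alone. The expected a number no higher from compound 2 to compound 3 (the limit leaves the size open) in this assay is small, with no shift beyond the scatter. For compound 3 the estimated half-life is 0.5 h, with an expected range from 0.25 h to 1 h.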

Compound 3, half-life: > 0.5 h
Compound 3: only a limit was reported; the forecaster's own chance of this, stated with the estimate: 55%; the middle value sits exactly at the limit.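

In this assay compound 3 gives > 0.5 h as a limit of the assay and not a number. For the compounds shown here, no step from compound 2 to compound 3 can be read, since both stand at a limit: the limit of > 0.5 h in this assay, at which 2 of the 3 values shown sit. Going by these compounds, the actual half-lives of compound 2 and compound 3, and whether ethyl and isopropyl differ at all here, stay open.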